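The source may report more compounds than this note shows. Statements on the series, on what has been measured and on what is new or still open speak of the compounds shown alone.

Compound 1, `COc1cccc(CN2CCc3cc(-c4ccc5[nH]ncc5c4)ccc3C2=O)c1`: in an assay on isolated protein for inhibition of Rho-associated protein kinase 1 (Homo sapiens), read by radiometric assay and 33P incorporation, with a stated time of 40 min, in the presence of a further agent that is not named here (a higher number here means a weaker inhibitor, a lower number a stronger inhibitor), compound 1 gives 2060 nM.
Compound 2, `COc1cccc(Cn2cnc3sc(-c4ccnc(Cl)c4)cc3c2=O)c1`: in this assay compound 2 gives > 10000 nM, a limit of the assay rather than a number.

Going by the values given here, of the two measured compounds, compound 1 is the one with a real number; compound 2 stands at the limit described by the limit of > 10000 nM in this assay, at which 1 of the 2 values shown sits, so all that is known of it is that it inhibits more weakly than the assay can resolve. Among the compounds with values here, no step between two measured compounds can be drawn here, since compound 1 and compound 2 differ in more than one place.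

Compound 3, `COc1cccc(Cn2cnc3sc(-c4ccc(N)nc4)cc3c2=O)c1`, has not yet been measured. It differs from compound 2 in one change: 6-aminopyridin-3-yl in place of 2-chloropyridin-4-yl on an aromatic carbon. Both aryl groups are six-membered rings with one ring nitrogen, but the entering group carries an amino group that the leaving group lacks, and the chlorine is gone.

With only a limit for compound 2, the size of the step can only be guessed. The expectation is a step from compound 2 to compound 3 of an at least 3.3-fold lower number from compound 2 to compound 3 (0.52 log units; beyond the scatter), toward stronger inhibition, and for compound 3 a value near 3000 nM, expected to lie between 500 nM and 20000 nM.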

Compound 3, half-maximal inhibitory concentration: > 10000 nM
Compound 3 gave a limit, no number; the forecaster's own chance of this, stated with the estimate: 30%; middle value at least 3.3-fold (0.52 log units) from the limit.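

Compound 2 and compound 3 both stand at a limit of the assay rather than at a number, so no step between them can be read: the limit of > 10000 nM in this assay, at which 2 of the 3 values shown sit.

The compounds shown leave open how strongly compound 2 and compound 3 actually inhibit, and whether putting 6-aminopyridin-3-yl in place of 2-chloropyridin-4-yl changes inhibition at all.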